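The compounds below may be only part of what the source reports. "The series", "measured", "known", "first", "only" and "open" are said of these compounds alone.

Measured compounds:
Compound 1, `CC(O)(CSc1ccc(F)cc1)C(=O)Nc1ccc(S(F)(F)(F)(F)F)cc1`: 13500 nM
Compound 2, `CC(O)(CSc1ccc(C(F)(F)F)cc1)C(=O)Nc1ccc(S(F)(F)(F)(F)F)cc1`: 14800 nM
Compound 3, `CC(O)(CS(=O)(=O)c1ccc(F)cc1)C(=O)Nc1ccc(S(F)(F)(F)(F)F)cc1`: 20600 nM

All three were tested in a functional assay on CWR22R cells (Homo sapiens) for antiproliferative activity, read by propidium iodide staining, with a stated time of 96 h; a higher number here means a weaker inhibitor, a lower number a stronger inhibitor. Compound 1 and compound 2 share a core and differ only by trifluoromethyl in place of fluoro on an aromatic carbon, and this change made a 1.1-fold higher number from compound 1 to compound 2 (0.04 log units; within the scatter). Compound 3 sits on a different core; how that core differs from the core of compound 1 is not broken down here, and the numbers of compound 3 and compound 1 lie within the scatter of each other, as do those of compound 3 and compound 2.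

Compound 4, `CC(O)(CS(=O)(=O)c1ccc(C(F)(F)F)cc1)C(=O)Nc1ccc(S(F)(F)(F)(F)F)cc1`, has not yet been measured in this assay. It differs from compound 3 by trifluoromethyl in place of fluoro on an aromatic carbon, the same change that was made from compound 1 to compound 2, at a place described in the same words. Among the measured compounds shown here, the only precedent for this change is the step of a 1.1-fold higher number from compound 1 to compound 2 (0.04 log units; within the scatter), which left the number essentially where it was. On that basis the step is expected to be about a 1.1-fold higher number from compound 3 to compound 4 (0.05 log units; within the scatter), because the earlier step of a 1.1-fold higher number from compound 1 to compound 2 (0.04 log units; within the scatter) was so small. Compound 4 is therefore estimated to give 23000 nM, with a range from 12000 nM to 45000 nM.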

Compound 4, half-maximal inhibitory concentration: 28900 nM
For compound 4 the middle estimate is 1.3-fold (0.10 log units) below the measured one; low and high end bracket the measured number.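

In this assay, putting trifluoromethyl in place of fluoro on the core of compound 3 gave a 1.4-fold higher number from compound 3 to compound 4 (0.15 log units; within the scatter), so the number again stayed within the scatter. Set beside the earlier step, the change behaved alike on the two cores: the same change on two cores in this assay, a 1.1-fold higher number (0.04 log units; within the scatter) from compound 1 to compound 2 and a 1.4-fold higher number (0.15 log units; within the scatter) from compound 3 to compound 4, 1.3-fold (0.11 log units) apart, within the scatter of two such steps

This shows that, on these two cores, swapping 4-fluorophenyl for 4-(trifluoromethyl)phenyl left the antiproliferative reading essentially unchanged; it does not show that the same would hold on any other core, and two small steps cannot reveal whether a larger effect would carry across in the same way.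

On these data alone, all four compounds carry either fluoro or trifluoromethyl on that aromatic carbon, so it remains open whether a nitrile, a methoxy group or an amine at that place would move the number beyond the scatter. As far as these compounds go, it also remains open what would happen if the pentafluorosulfanyl group were replaced by a nitrile or a nitro group.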